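Adding a 2-acetamidoethyl arm to the aniline nitrogen

The source may hold more compounds than are shown below. What is called first, only, known or untested is meant among the compounds shown, and "the series" means these compounds.

Going by the values given here, the shared core appears in compound 2 `CC1(C)Oc2ccc(C#N)cc2[C@H](Nc2ccccc2)[C@H]1O`, which in a functional assay (aorta) with Rattus norvegicus as the target (a lower number here means a stronger inhibitor, a higher number a weaker inhibitor), gives 1200 nM and is the only compound with a numerical result. Compound 1 `CCOC(=O)CN(c1ccccc1)C1c2cc(C#N)ccc2OC(C)(C)C1O` reaches only a limit of the assay, > 30000 nM. Compound 3 `CCOC(=O)CN(c1ccc(Cl)cc1)[C@H]1c2cc(C#N)ccc2OC(C)(C)[C@@H]1O` likewise stands at a limit, > 30000 nM; both share the observation that (the limit of > 30000 nM in this assay, at which 2 of the 3 values shown sit). Compound 4 `CC(=O)NCCN(c1ccccc1)[C@H]1c2cc(C#N)ccc2OC(C)(C)[C@@H]1O` carries the change (2-acetamidoethyl in place of hydrogen on a nitrogen on an aromatic ring), where compounds 1 and 3 also bear a substituent on that nitrogen. Compound 4 is expected to be weaker than compound 2 by a step of about a 10-fold higher number from compound 2 to compound 4 (1.00 log units; beyond the scatter), beyond the usual scatter. In this assay compound 4 is therefore estimated at 12000 nM, between 3000 nM and 50000 nM, with a real chance of only a limit.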

Compound 4, half-maximal inhibitory concentration: > 30000 nM
Compound 4: no number, only a limit; the forecaster's own chance of this, stated with the estimate: 45%; at least 2.5-fold (0.39 log units) between middle value and limit.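

Going by these compounds alone, the step of an at least 25-fold higher number from compound 2 to compound 4 (1.39 log units; beyond the scatter) is the first that can be read at this position, and it shows that 2-acetamidoethyl in place of hydrogen on a nitrogen on an aromatic ring costs much of the activity in this assay. Compound 4 gives only a limit of the assay, and it joins the other compounds substituted on that nitrogen there: the limit of > 30000 nM in this assay, at which 3 of the 4 values shown sit.

From the compounds shown here alone, whether a methyl group on that nitrogen would keep the activity of compound 2 stays open. So does whether an amine or a carboxylic acid at the end of the chain would change the result.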